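Cyclobutyl series: phenyl to 4-chloro-2-cyanophenyl

The compounds below may be only part of what the source reports. "The series", "measured", "known", "first", "only" and "open" are said of these compounds alone.

In a functional assay on MCF7 cells (Homo sapiens) for antiproliferative activity, read by CellTiter-Glo, with a stated time of 5 days (on this read-out higher numbers stand for weaker inhibition and lower numbers for stronger inhibition), compound 1 (`CC/C(=C(/c1ccc(/C=C/C(=O)O)cc1)c1ccc2nccn2c1)c1ccccc1`) gives 170 nM and compound 2 (`CC/C(=C(/c1ccc(/C=C/C(=O)O)cc1)c1ccc2scnc2c1)c1ccccc1`) gives 90 nM on the same read-out. Compound 3 (`O=C(O)/C=C/c1ccc(/C(=C(\c2ccccc2)C2CCC2)c2ccc3scnc3c2)cc1`) gives 16 nM in this assay and holds the lowest number of the three, clear of the scatter against both others. Compound 4 (`N#Cc1cc(Cl)ccc1/C(=C(\c1ccc(/C=C/C(=O)O)cc1)c1ccc2scnc2c1)C1CCC1`) carries 4-chloro-2-cyanophenyl in place of phenyl on a double-bonded chain carbon bound to a double-bonded chain carbon and a saturated ring carbon. Among the compounds with values here, no measured step touches this phenyl, and no substituted phenyl has a number yet. The nearest evidence is a 5.6-fold lower number from compound 2 to compound 3 (0.75 log units; beyond the scatter) on the same double-bonded chain carbon, with cyclobutyl in place of ethyl. The other measured step is a 1.9-fold lower number from compound 1 to compound 2 (0.28 log units; within the scatter) at a different place and offers little guidance here. Within the data shown here, a modest move is therefore expected, no larger than the step to compound 3 and uncertain in size. The expected step is a 2.7-fold lower number from compound 3 to compound 4 (0.43 log units; beyond the scatter) in this assay with a wide margin. The estimate for compound 4 is 6 nM with an expected range from 1.5 nM to 20 nM for now.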

Compound 4, half-maximal inhibitory concentration: 0.9 nM
Beside the measured number, compound 4's estimate is 6.7-fold (0.82 log units) above it, outside the stated range (below it).
By their numbers in this assay, from the lowest: compound 4; then compound 3; then compounds 2 and 1 (each within the scatter of the next).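

In this assay, the phenyl on the double-bonded chain carbon bound to a double-bonded chain carbon and a saturated ring carbon proves to be a place where substitution pays, with an 18-fold lower number from compound 3 to compound 4 (1.25 log units; beyond the scatter), and the step is rated large. The change brings in the chlorine and the nitrile together, so this single step cannot be divided between the two groups. Nothing at hand accounts for the size of the gain.

The compounds shown leave open whether the chlorine alone or the nitrile alone would give a comparable step, and how a different group on this phenyl, such as a trifluoromethyl or an amine, would read. They also leave open whether 4-chloro-2-cyanophenyl gives a step of this size with ethyl in place of cyclobutyl.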